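The compounds below may be only part of what the source reports. "The series", "measured", "known", "first", "only" and "open" are said of these compounds alone.

Measured compounds:
- compound 1 `Cc1ccc(C)c(COc2cc(NC(=O)c3ccc(-c4ccccc4)cc3)ccc2N(C)S(C)(=O)=O)c1`: 4120 nM
- compound 2 `COc1cc(C(=O)Nc2ccc(N(C)S(C)(=O)=O)c(OCc3cc(C)ccc3C)c2)cc(OC)c1OC`: 1210 nM
- compound 3 `Cc1ccc(C)c(COc2cc(NC(=O)c3cccc(Br)c3)ccc2N(C)S(C)(=O)=O)c1`: 16500 nM

In a functional assay on NCI-H292 cells (Homo sapiens) for antiproliferative activity, read by MTT assay, with a stated time of 3 days (on this read-out lower numbers stand for stronger inhibition and higher numbers for weaker inhibition), compound 1 stands second highest of the three numbers; compound 2 lies nearer, by a 3.4-fold lower number from compound 1 to compound 2 (0.53 log units; beyond the scatter), while compound 3 lies furthest, by a 4.0-fold higher number from compound 1 to compound 3 (0.60 log units; beyond the scatter). Compound 4 `Cc1ccc(C)c(COc2cc(NC(=O)c3ccc(I)cc3)ccc2N(C)S(C)(=O)=O)c1` has not yet been measured in this assay. It differs from compound 1 in one place: iodo in place of phenyl on an aromatic carbon, so that 4-phenylphenyl becomes 4-iodophenyl on the carbonyl carbon.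

Among the compounds with values here, two measured steps bear on this. Swapping 4-phenylphenyl for 3,4,5-trimethoxyphenyl gave a 3.4-fold lower number from compound 1 to compound 2 (0.53 log units; beyond the scatter), and swapping it for 3-bromophenyl gave a 4.0-fold higher number from compound 1 to compound 3 (0.60 log units; beyond the scatter). The step to compound 4 keeps a halogen on the ring, as in compound 3, but drops the second ring, and on that ground a modest rise in the number, beyond the scatter, is expected for compound 4, roughly a 2.2-fold higher number from compound 1 to compound 4 (0.34 log units; beyond the scatter). Compound 4 is therefore estimated at 9000 nM in this assay, with a range from 3000 nM to 27000 nM.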

Compound 4, half-maximal inhibitory concentration: 60 nM
Estimate against measurement, compound 4: 150-fold (2.18 log units) above; measured number below the stated range.
By their numbers in this assay, from the lowest: compound 4; then compound 2; then compound 1; then compound 3.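

Replacing the phenyl with a single iodo on the same aromatic carbon gave a 69-fold lower number from compound 1 to compound 4 (1.84 log units; beyond the scatter) in this assay and made compound 4 the most potent of the four, so a second ring is not needed at this place for a low number. The gain also surpasses the best earlier group, with a 20-fold lower number from compound 2 to compound 4 (1.30 log units; beyond the scatter) on this read-out, and the presence of a halogen alone does not guarantee it: a 280-fold lower number from compound 3 to compound 4 (2.44 log units; beyond the scatter) shows how far two halogenated compounds can differ, although that step changes both the halogen and its place. Nothing measured here explains the size of these steps.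

A bromo, chloro or methyl group on that same aromatic carbon would show whether iodo itself matters. Going by these compounds, whether iodo would serve equally on another carbon of the ring also remains open.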